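A few compounds are considered here, and "the series" means these few. Any claim that something is new, unique, unknown or untested is made for them only; others in the source may bear on it.

Measured so far:
compound 1 `Nc1nc(Cl)c2ncn(Cc3ccc(CCl)cc3)c2n1` — 3630 nM
compound 2 `ClCc1ccccc1Cn1cnc2nc(Cl)nc(Cl)c21` — 250 nM

Both compounds were run in a functional assay on K562 cells (Homo sapiens) for cytotoxicity, read by sulforhodamine B assay, with a stated time of 48 h; on this read-out higher numbers stand for weaker inhibition of growth and lower numbers for stronger inhibition of growth. Compound 2 gives the lowest of the two numbers in this assay; the nearest number is that of compound 1, which lies a wide gap higher, beyond the scatter. Within the data shown here, compound 1 and compound 2 differ in more than one place, so no single step connects them; their two values show only that compound 2 inhibits growth more strongly.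

Compound 3 `ClCc1ccccc1Cn1cnc2ncnc(Cl)c21` has not yet been measured in this assay. It differs from compound 2 by hydrogen in place of chloro on an aromatic carbon. Among the measured compounds shown here, no step between measured compounds isolates this change, so the expected size rests on the number for compound 2 alone. A moderate step toward weaker inhibition of growth is expected, a 2.4-fold higher number from compound 2 to compound 3 (0.38 log units; beyond the scatter), with no certainty that it will exceed the scatter. Compound 3 is thus estimated at 600 nM in this assay, within a range from 200 nM to 2000 nM.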

Compound 3, concentration for 50% growth inhibition: 2230 nM
For compound 3 the middle estimate is 3.7-fold (0.57 log units) below the measured one; measured number above the stated range.
By their numbers in this assay, from the lowest: compound 2; then compounds 3 and 1 (each within the scatter of the next).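

In this assay, among these compounds, the chloro on the aromatic carbon between two ring nitrogen atoms matters to growth inhibition: hydrogen in its place gives an 8.9-fold higher number from compound 2 to compound 3 (0.95 log units; beyond the scatter) and is the first change that can be read on its own. The step removes a single chlorine atom, adds no ring and leaves the other chloro in place, so this one position alone can shift the number beyond the scatter. Nothing available explains the size of this step.

From the compounds shown here alone, it remains open whether other replacements at this position, such as fluoro, bromo, methyl or methoxy, would keep the number of compound 2 or move it toward that of compound 3. Going by these compounds, it is also open whether the same change would have a similar effect with a differently substituted benzyl group.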